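Series notes: replacing 1H-indol-1-yl on the chain carbon

A few compounds are considered here, and "the series" means these few. Any claim that something is new, unique, unknown or untested is made for them only; others in the source may bear on it.

Measured in a functional assay on HepG2 cells (Homo sapiens) for antiproliferative activity, read by MTT assay, with a stated time of 48 h; a higher number here means a weaker inhibitor, a lower number a stronger inhibitor:
- compound 1 `COc1ccc(CN(C(=O)Cn2cc(CSc3nc4ccccc4s3)nn2)c2cc(OC)c(OC)c(OC)c2)cc1`: 49200 nM
- compound 2 `COc1ccc(CN(C(=O)Cn2cc(Cn3ccc4ccccc43)nn2)c2cc(OC)c(OC)c(OC)c2)cc1`: 40100 nM

Compound 2, at 40100 nM, cannot be ranked against compound 1, as the two values lie within the scatter of each other. Compound 3 `COc1ccc(CN(C(=O)Cn2cc(CNS(=O)(=O)c3ccc(C)cc3)nn2)c2cc(OC)c(OC)c(OC)c2)cc1` is still to be measured. It carries ((4-methylphenyl)sulfonyl)amino in place of 1H-indol-1-yl on a saturated chain carbon bound to an aromatic carbon. Within the data shown here, only one measured step bears on this place, a 1.2-fold lower number from compound 1 to compound 2 (0.09 log units; within the scatter), and it stayed within the scatter. Among the measured compounds shown here, no measured compound carries the entering group, so that step is a weak guide and the range is kept wide. The expected change is a 1.1-fold lower number from compound 2 to compound 3 (0.06 log units; within the scatter), which means no step beyond the scatter is expected in this assay. For compound 3 the estimated value is 35000 nM, with an expected range of 12000 nM to 90000 nM.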

Compound 3, half-maximal inhibitory concentration: 30500 nM
Estimate against measurement, compound 3: 1.1-fold (0.06 log units) above; the range from low to high includes it.
By their numbers in this assay, from the lowest: compounds 3, 2 and 1 (each within the scatter of the next).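

In this assay, placing ((4-methylphenyl)sulfonyl)amino on the saturated chain carbon bound to an aromatic carbon gives a 1.3-fold lower number from compound 2 to compound 3 (0.12 log units; within the scatter) and, against the other earlier group, a 1.6-fold lower number from compound 1 to compound 3 (0.21 log units; within the scatter). The entering group carries a hydrogen-bond donor that 1H-indol-1-yl lacks and has no five-membered aromatic ring, yet neither difference separates compound 3 from compound 2 in this assay, so three structurally different groups at this place now cannot be ranked. Nothing available explains this result.

As far as these compounds go, whether any group at this place can produce a step beyond the scatter remains open. A primary amine, a carboxylic acid or a longer chain on this carbon would test that, as all three groups so far contain an aromatic ring.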